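The source may hold more compounds than are shown below. What is called first, only, known or untested is meant among the compounds shown, and "the series" means these compounds.

Three compounds have been measured in an assay on cells for displacement of a labelled ligand from prostaglandin E2 receptor EP4 subtype (Homo sapiens), read by scintillation counting; a lower number here means a stronger inhibitor, a higher number a weaker inhibitor:

compound 1 `COc1ccc(-c2ccc(OCc3cc(C(=O)NS(=O)(=O)c4c(C)noc4C)oc3C)cc2)nc1`: 13 nM
compound 2 `Cc1oc(CCC(=O)O)cc1COc1ccc(-c2ccccc2)cc1`: 80 nM
compound 3 `COc1ccc(-c2ccc(OCc3cc(C(=O)NS(=O)(=O)c4c(C)noc4C)oc3C)cc2)c(C)c1`: 24 nM

Compound 3 stands second highest of these three numbers; its nearest neighbour is compound 1, within the scatter, and its furthest is compound 2, beyond the scatter. Compound 4 `COc1ccc(-c2ccc(OCc3cc(C(=O)NS(=O)(=O)c4ccccc4)oc3C)cc2)c(C)c1` differs from compound 3 in one place: phenyl in place of 3,5-dimethyl-1,2-oxazol-4-yl on a sulfonyl sulfur. Within the data shown here, no measured step alters the group on the sulfonyl sulfur. Among the measured compounds shown here, the only single-site step, a 1.8-fold higher number from compound 1 to compound 3 (0.27 log units; within the scatter), concerns a different place and so gives no guide to this change; compound 2 differs from the others in several places at once. Without a direct precedent, the expected step is modest, a 1.7-fold higher number from compound 3 to compound 4 (0.22 log units; within the scatter), towards a somewhat higher number. Compound 4 is therefore estimated at 40 nM, with a range from 12 nM to 130 nM.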

Compound 4, inhibition constant: 21 nM
Beside the measured number, compound 4's estimate is 1.9-fold (0.28 log units) above it, within the range that was stated.
By their numbers in this assay, from the lowest: compounds 1, 4 and 3 (each within the scatter of the next); then compound 2.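

Phenyl in place of 3,5-dimethyl-1,2-oxazol-4-yl on the sulfonyl sulfur gives a 1.1-fold lower number from compound 3 to compound 4 (0.06 log units; within the scatter) in this assay and the two numbers cannot be told apart. Among these compounds, this is the first measured step at this position, and it shows that a ring of carbon only can stand here in place of the ring with nitrogen and oxygen without a difference beyond the scatter. No measurement shown accounts for this result.

Still open, on these data alone, is whether a small chain such as methyl, or a phenyl carrying a chlorine or an amine, would fit here as well. The same swap on compound 1 also remains an open question.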